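Cyanophenyl ureas and thioureas on a chromanyl methanesulfonamide core

This account rests on a few compounds, and the source may have more. Where it says the series, first, only, none or still open, it means among the compounds named here.

Compound 1 `CC1(C)CC(NC(=S)Nc2cccc(C#N)c2)c2cc(NS(C)(=O)=O)ccc2O1` gives 9800 nM in a functional assay on thoracic aorta (Rattus norvegicus) for inhibition; a lower number here means that less compound is needed, a higher number that more compound is needed for the effect. Compound 2 `CC1(C)CC(NC(=S)Nc2ccc(C#N)cc2)c2cc(NS(C)(=O)=O)ccc2O1` gives 11600 nM in this assay; the pair shows a 1.2-fold higher number from compound 1 to compound 2 (0.07 log units; within the scatter), the change being (4-cyanophenyl in place of 3-cyanophenyl on an amide-type nitrogen). Compound 3 `CC1(C)CC(NC(=O)Nc2cccc(C#N)c2)c2cc(NS(C)(=O)=O)ccc2O1` gives 9300 nM in this assay; its values against compound 1 and compound 2 all lie within the scatter, so no order among the three is read. The difference between the core of compound 3 and the core of compound 1 is not broken down here.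

Compound 4 `CC1(C)CC(NC(=O)Nc2ccc(C#N)cc2)c2cc(NS(C)(=O)=O)ccc2O1` has not yet been measured in this assay. It differs from compound 3 by 4-cyanophenyl in place of 3-cyanophenyl on an amide-type nitrogen. This is the same kind of change as from compound 1 to compound 2, but not the same: around the place the other neighbour of the amide-type nitrogen is a carbonyl carbon in compound 3 and compound 4, and a thiocarbonyl carbon in compound 1 and compound 2. For the measured compounds named here, a step of a 1.2-fold higher number from compound 3 to compound 4 (0.07 log units; within the scatter) is expected, since the only measured instance of this change is a 1.2-fold higher number from compound 1 to compound 2 (0.07 log units; within the scatter), which lies within the scatter. For compound 4 the estimated value is 11000 nM, expected between 5500 nM and 22000 nM.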

Compound 4, half-maximal effective concentration: 19800 nM
For compound 4 the middle estimate is 1.8-fold (0.26 log units) below the measured one, and the stated range covers the measured number.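

In this assay, replacing 3-cyanophenyl with 4-cyanophenyl on the amide-type nitrogen whose other neighbour is a carbonyl carbon gives a 2.1-fold higher number from compound 3 to compound 4 (0.33 log units; beyond the scatter), a modest step that only just clears the scatter. Set beside the same change where that neighbour is a thiocarbonyl carbon, the step does not separate the two cores: the same change on two cores in this assay, a 1.2-fold higher number (0.07 log units; within the scatter) from compound 1 to compound 2 and a 2.1-fold higher number (0.33 log units; beyond the scatter) from compound 3 to compound 4, 1.8-fold (0.25 log units) apart, within the scatter of two such steps. For the compounds shown here, the change can therefore be carried between these cores as far as two pairs can show, but this does not establish that its size is the same on both, and only the pair with the carbonyl carbon gives a step beyond the scatter.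

Going by these compounds, whether the step holds when the nitrile on the phenyl ring gives way to a methoxy group or a carboxylic acid remains open. Also open, on these data alone, is how either pair would respond if the methanesulfonamide gave way to an acetamide.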